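This account rests on a few compounds, and the source may have more. Where it says the series, first, only, none or still open, it means among the compounds named here.

Compound 2 `Cc1cc(=O)n(-c2ccccc2OC(F)(F)F)nc1C(=O)Nc1ccc(Oc2ncnc3ccsc23)c(F)c1` is tested in a functional assay on A549 cells (Homo sapiens) for cytotoxicity, read by MTT assay, with a stated time of 72 h (a higher number here means a weaker inhibitor, a lower number a stronger inhibitor), where compound 2 gives 5720 nM. Within the data shown here, the only other compound measured in this assay is compound 1 `CNC(=O)c1cc(Oc2ccc(NC(=O)c3nn(-c4ccc(C)cc4)c(=O)cc3C)cc2F)ccn1`, and in this assay compound 1 gives 11500 nM; the two numbers lie within the usual scatter of each other, so no order between them is claimed. Compound 3 `Cc1ccc(-n2nc(C(=O)Nc3ccc(Oc4ncnc5ccsc45)c(F)c3)c(C)cc2=O)cc1` differs from compound 2 by 4-methylphenyl in place of 2-(trifluoromethoxy)phenyl on an aromatic nitrogen. Among the measured compounds shown here, no measured pair shows this change alone, so the step from compound 2 to compound 3 is expected to stay within the scatter, with a 1.1-fold higher number from compound 2 to compound 3 (0.06 log units; within the scatter) anticipated. In this assay compound 3 is therefore estimated at 6500 nM, in the range 2000 nM to 20000 nM.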

Compound 3, half-maximal inhibitory concentration: 5890 nM
The estimate for compound 3 lay 1.1-fold (0.04 log units) above the measured number, and the stated range covers the measured number.
By their numbers in this assay, from the lowest: compounds 2, 3 and 1 (each within the scatter of the next).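

Within this assay, the pair of compound 2 and compound 3 now isolates the change on the aromatic nitrogen, and 4-methylphenyl in place of 2-(trifluoromethoxy)phenyl gives a 1.0-fold higher number from compound 2 to compound 3 (0.01 log units; within the scatter) and so no readable difference at this position. Exchanging the group on the oxygen on an aromatic ring gives a 2.0-fold lower number from compound 1 to compound 3 (0.29 log units; within the scatter) and is likewise within the scatter. No measured property bears on either result.

On these data alone, what an amine-bearing phenyl, a carboxylic acid on that phenyl or a plain alkyl chain on the aromatic nitrogen would give remains open. The compounds shown cover only two aryl groups at this position.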